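Dropping One Fluoro from Compound 2: Expected Clearance

The source may hold more compounds than are shown below. What is called first, only, known or untested is meant among the compounds shown, and "the series" means these compounds.

Three compounds have been measured in an ADME assay on microsomes from liver (Homo sapiens) for metabolic stability, tested at 2.5 uM; a higher number here means faster removal of the compound, a lower number slower removal:

Compound 1, `O=S(=O)(c1cc(F)cc(F)c1)c1cnc2c(F)cccc2c1-c1cccc(Cl)c1`, gives 0.64 mL/min.
Compound 2, `COc1cccc(-c2c(S(=O)(=O)c3cc(F)cc(F)c3)cnc3c(F)cccc23)c1`, gives 2.76 mL/min.
Compound 3, `O=S(=O)(c1cc(F)cc(F)c1)c1cnc2c(F)cccc2c1-c1cccc(F)c1`, gives 1.18 mL/min.

Compound 2 stands highest of the three in this assay; the nearest is compound 3, a 2.3-fold lower number from compound 2 to compound 3 (0.37 log units; beyond the scatter), and the furthest is compound 1, a 4.3-fold higher number from compound 1 to compound 2 (0.63 log units; beyond the scatter). Compound 4, `COc1cccc(-c2c(S(=O)(=O)c3cccc(F)c3)cnc3c(F)cccc23)c1`, differs from compound 2 by hydrogen in place of fluoro on an aromatic carbon.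

Among the compounds with values here, none of the measured steps bears directly on this change: the steps from compound 1 to compound 2, from compound 1 to compound 3 and from compound 2 to compound 3 all alter the other aromatic ring, where chloro, fluoro and methoxy are exchanged, and their sizes range from within the scatter to modest. Within the data shown here, the ring that changes in compound 4 is the same in all three measured compounds, so the data give no measured step for removing a fluoro there. The expectation for compound 4 is therefore a step of a 1.1-fold higher number from compound 2 to compound 4 (0.04 log units; within the scatter), within the scatter, and compound 4 is estimated at 3 mL/min, with a range from 1.4 mL/min to 6.5 mL/min.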

Compound 4, intrinsic clearance in a liver preparation (reported as CLH), per the amount of preparation that the assay uses: 2.6 mL/min
Compound 4: the middle estimate sits 1.2-fold (0.06 log units) above what was measured, within the range that was stated.
By their numbers in this assay, from the lowest: compounds 1 and 3 (each within the scatter of the next); then compounds 4 and 2 (each within the scatter of the next).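

Within the data shown here, the change from 3,5-difluorophenyl to 3-fluorophenyl is the first step on this ring, and in this assay it gives a 1.1-fold lower number from compound 2 to compound 4 (0.03 log units; within the scatter). With methoxy on the other aromatic ring, this fluoro can therefore be replaced by hydrogen with no change that stands out from the scatter, whereas two of the three earlier steps, all on the other ring, lay beyond it. No measurement shown here accounts for this result.

From the compounds shown here alone, it remains open whether the same swap would stay as small in compound 1 or compound 3, which carry chloro and fluoro where compound 2 carries methoxy. Going by these compounds, the effect of putting an amine or a carboxylic acid at this place, rather than hydrogen, also remains open.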